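This account rests on a few compounds, and the source may have more. Where it says the series, first, only, none or still open, it means among the compounds named here.

In a physicochemical assay, read by spectrophotometry, with a stated time of 10 min (on this read-out lower numbers stand for an effect already at smaller amounts and higher numbers for an effect only at larger amounts of compound), three compounds sharing one core have been measured. Compound 1 (`CCOC(=O)C1=C(C[Se]C(=O)c2ccc(C)cc2)NC(=O)NC1c1cccc([N+](=O)[O-])c1`) gives 24500 nM as its value, compound 2 (`CCOC(=O)C1=C(C[Se]C(=O)c2ccc(C)cc2)NC(=O)NC1c1ccc(OC)cc1`) gives 22500 nM as its value, and compound 3 (`CCOC(=O)C1=C(C[Se]C(=O)c2ccc(C)cc2)NC(=O)NC1c1ccc(C)cc1`) gives 21200 nM as its value. Compound 3 thus stands level with the other two, within the scatter of both.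

The next compound is compound 4 (`CCOC(=O)C1=C(C[Se]C(=O)c2ccc(C)cc2)NC(=O)NC1c1ccccc1`). It carries hydrogen in place of methyl on an aromatic carbon.

The closest measured change is the one at that aromatic carbon, where methyl replaced methoxy (a 1.1-fold lower number from compound 2 to compound 3 (0.03 log units; within the scatter)). Two wider changes of the aromatic group were just as small (a 1.1-fold lower number from compound 1 to compound 2 (0.04 log units; within the scatter); a 1.2-fold lower number from compound 1 to compound 3 (0.06 log units; within the scatter)). None of the three measured steps goes beyond the scatter, although none of them shows a compound with hydrogen at that place. No step beyond the scatter is therefore expected in this assay, in either direction.

The expected step is small (a 1.0-fold higher number from compound 3 to compound 4 (0.02 log units; within the scatter)). For compound 4 the estimated value is 22000 nM, with an expected range from 14000 nM to 34000 nM.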

Compound 4, half-maximal effective concentration: 10500 nM
For compound 4 the middle estimate is 2.1-fold (0.32 log units) above the measured one, and the stated range ends above it.
By their numbers in this assay, from the lowest: compound 4; then compounds 3, 2 and 1 (each within the scatter of the next).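

In this assay, hydrogen on this aromatic ring sets the compound apart from the three substituted ones, which stand level with one another: hydrogen in place of methyl gives a 2.0-fold lower number from compound 3 to compound 4 (0.31 log units; beyond the scatter), hydrogen in place of methoxy gives a 2.1-fold lower number from compound 2 to compound 4 (0.33 log units; beyond the scatter), and hydrogen in place of nitro gives a 2.3-fold lower number from compound 1 to compound 4 (0.37 log units; beyond the scatter). Methyl, methoxy and nitro differ from one another, yet each of the three compounds carrying one stands apart from compound 4 by a modest step, so among these four compounds the presence of a group counts for more than which group it is. Nothing available explains why this should be so.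

On these data alone, it remains open whether a chlorine, an amine or a carboxylic acid on this ring would stand with the three substituted compounds or with compound 4. As far as these compounds go, it is also open whether the same step would appear with a longer chain in place of the ethyl ester on the shared core.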